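This account rests on a few compounds, and the source may have more. Where it says the series, first, only, none or still open, it means among the compounds named here.

Working notes on the series, read in a functional assay on CNE-2 cells (Homo sapiens) for antiproliferative activity, read by sulforhodamine B assay, with a stated time of 48 h; on this read-out lower numbers stand for stronger inhibition and higher numbers for weaker inhibition. Compound 1 (`COc1cc(C=C(C(=O)/C=C/c2cccc(OC)c2OC)C(=O)/C=C/c2cccc(OC)c2OC)ccc1O`) gives 280 nM, compound 2 (`COc1cccc(/C=C/C(=O)C(=Cc2cc(OC)c(OC)c(OC)c2)C(=O)/C=C/c2cccc(OC)c2OC)c1OC`) gives 400 nM and compound 3 (`COc1cccc(/C=C/C(=O)C(=Cc2ccc(O)c(F)c2)C(=O)/C=C/c2cccc(OC)c2OC)c1OC`) gives 260 nM. Compound 3 therefore stands with the other two, all three within the scatter of each other.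

The next change leads to compound 4 (`COc1cc(C=C(C(=O)/C=C/c2cccc(OC)c2OC)C(=O)/C=C/c2cccc(OC)c2OC)cc(Br)c1O`), with 3-bromo-4-hydroxy-5-methoxyphenyl in place of 3-fluoro-4-hydroxyphenyl on a double-bonded chain carbon bound to a double-bonded chain carbon.

For the measured compounds named here, three measured steps bear on this change, all at the same chain carbon. Fluoro in place of methoxy gave a 1.1-fold lower number from compound 1 to compound 3 (0.03 log units; within the scatter). The swap of the whole aryl group gave a 1.5-fold lower number from compound 2 to compound 3 (0.19 log units; within the scatter) and a 1.4-fold higher number from compound 1 to compound 2 (0.15 log units; within the scatter). Each stayed within the scatter, so no shift beyond the scatter is expected from another change at this place. Going by the values given here, no measured compound carries bromo, which leaves that part of the change untested and widens the range.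

The estimated step is a 1.1-fold higher number from compound 3 to compound 4 (0.03 log units; within the scatter), which stays within the scatter. For compound 4 the expected value is 280 nM, with an estimated range of 120 nM to 650 nM.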

Compound 4, half-maximal inhibitory concentration: 220 nM
Estimate against measurement, compound 4: 1.3-fold (0.10 log units) above; low and high end bracket the measured number.
By their numbers in this assay, from the lowest: compounds 4, 3, 1 and 2 (each within the scatter of the next).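

Bromo in place of hydrogen on an aromatic carbon gives a 1.3-fold lower number from compound 1 to compound 4 (0.10 log units; within the scatter) and is the first reading of bromo at this place. The whole-group swaps give a 1.2-fold lower number from compound 3 to compound 4 (0.07 log units; within the scatter) and a 1.8-fold lower number from compound 2 to compound 4 (0.26 log units; within the scatter) in this assay and so extend the earlier picture: with a larger group carrying bromo, hydroxy and methoxy on the ring, every step among the four compounds on this double-bonded chain carbon stays within the scatter. No measurement at hand gives a reason for this result.

Going by these compounds, whether an amine or a carboxylic acid on this phenyl ring would move the number beyond the scatter remains open. On these data alone, the core of compound 1 is shared by all four compounds, so the effect of changes to that core also remains open.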